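Aminoacyl amides on the shared core: next step

This account rests on a few compounds, and the source may have more. Where it says the series, first, only, none or still open, it means among the compounds named here.

Measured so far in a functional assay on HCT-116 cells (Homo sapiens) for antiproliferative activity; a higher number here means a weaker inhibitor, a lower number a stronger inhibitor:
- compound 1 `CC(=O)N1CCc2c(C)c3c(n2-c2ccc(C(N)=O)c(c2)N[C@@H](C)[C@H](C)C1)CC(C)(C)CC3=O` gives 24 nM
- compound 2 `CC[C@H](N)C(=O)N1CCc2c(C)c3c(n2-c2ccc(C(N)=O)c(c2)N[C@@H](C)[C@H](C)C1)CC(C)(C)CC3=O` gives 33 nM

Compound 2 at 33 nM stands within the scatter of compound 1. Next comes compound 3 `Cc1c2c(n3c1CCN(C(=O)C1(N)CCCC1)C[C@@H](C)[C@H](C)Nc1cc-3ccc1C(N)=O)CC(C)(C)CC2=O`, with 1-aminocyclopentyl in place of 1-aminopropyl on a carbonyl carbon. For the measured compounds named here, only one measured step bears on this place, a 1.4-fold higher number from compound 1 to compound 2 (0.14 log units; within the scatter), and it is small. As far as these compounds go, no step beyond the scatter is therefore expected in this assay, though a ring at this place is untested. The expected step is a 1.1-fold lower number from compound 2 to compound 3 (0.04 log units; within the scatter). Compound 3 is estimated at 30 nM, within an expected range of 12 nM to 75 nM.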

Compound 3, half-maximal inhibitory concentration: 27 nM
For compound 3 the middle estimate is 1.1-fold (0.05 log units) above the measured one, and the stated range covers the measured number.
By their numbers in this assay, from the lowest: compounds 1, 3 and 2 (each within the scatter of the next).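

In this assay, 1-aminocyclopentyl on the carbonyl carbon gives a 1.2-fold lower number from compound 2 to compound 3 (0.09 log units; within the scatter) and, against methyl, a 1.1-fold higher number from compound 1 to compound 3 (0.05 log units; within the scatter) as well. A five-membered non-aromatic ring of carbon is therefore accommodated at this place, with the amine retained, which the open-chain 1-aminopropyl of compound 2 could not show. No evidence available here bears on this result.

Whether the amine matters on the ring remains open, since plain cyclopentyl is absent from the compounds shown. As far as these compounds go, a larger ring such as 1-aminocyclohexyl, or a phenyl ring, also remains open at this place.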